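This account rests on a few compounds, and the source may have more. Where it says the series, first, only, none or still open, it means among the compounds named here.

Of the compounds shown here, three of a shared core have been measured in a functional assay on the whole organism (strain Kunming) for inhibition, with Mus musculus as the target, with a stated time of 1 h, at a dose of 40 mg/kg by the oral route (a higher number here means more inhibition at the dose given (going by the name of the read-out), a lower number less inhibition), so far. Compound 1 `O=C(/C=C/c1ccccc1)c1ccc(N2CCN(c3ccc([N+](=O)[O-])cc3)CC2)cc1` gives 55.4% in this assay. Compound 2 `O=C(/C=C/c1ccccc1)c1ccc(N2CCN(c3cccc(Cl)c3)CC2)cc1` gives 14.1% in this assay. Compound 3 `Cc1ccc(S(=O)(=O)N2CCN(c3ccc(C(=O)/C=C/c4ccccc4)cc3)CC2)cc1` gives 30.8% in this assay and stands second highest of the three: it lies a number 16.7 percentage points higher from compound 2 to compound 3 (beyond the scatter) and a number 24.6 percentage points lower from compound 1 to compound 3 (beyond the scatter) in this assay. The widest gap in the set is a number 41.3 percentage points lower from compound 1 to compound 2 (beyond the scatter) in this assay. Every measured step exchanges the whole group on the amine nitrogen in the ring.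

Compound 4 `O=C(/C=C/c1ccccc1)c1ccc(N2CCN(S(=O)(=O)c3ccc(Br)cc3)CC2)cc1` differs from compound 3 in one place, bromo in place of methyl on an aromatic carbon while the rest of the structure is kept. For the measured compounds named here, no measured step alters a substituent within the (4-methylphenyl)sulfonyl group, so none bears directly on this change; the two steps involving compound 3 only fix where the sulfonyl member stands. With no guide to direction, the step of a number 0.8 percentage points lower from compound 3 to compound 4 (within the scatter) is expected to stay within the scatter of this assay. Compound 4 is therefore estimated at 30% with a range from 15% to 48% in this assay.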

Compound 4, a percentage reported as inhibition, in the whole organism at one dose (the size of the read-out at that dose, not a potency): 47.4%
Compound 4: middle estimate off by 17.4 percentage points, on the low side; the range from low to high includes it.
By their numbers in this assay, from the lowest: compound 2; then compound 3; then compounds 4 and 1 (each within the scatter of the next).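

In this assay the substituent on the aromatic ring of the sulfonyl group proves not to be silent: bromo in place of methyl, para to a large group, gives a number 16.6 percentage points higher from compound 3 to compound 4 (beyond the scatter), a modest step for the exchange of one heavy atom. With bromo in this place the sulfonyl member lies clear of the 3-chlorophenyl member, with a number 33.3 percentage points higher from compound 2 to compound 4 (beyond the scatter), and can no longer be separated from the 4-nitrophenyl member, with a number 8 percentage points lower from compound 1 to compound 4 (within the scatter), which compound 3 did not achieve. Nothing available explains this step.

Only methyl and bromo are shown on this ring, so it remains open whether other groups at the same place, such as fluoro, methoxy or a carboxylic acid, would follow the same direction. On these data alone, it also remains open whether bromo would have a similar effect on the aromatic ring of compound 2.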